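A few compounds are considered here, and "the series" means these few. Any claim that something is new, unique, unknown or untested is made for them only; others in the source may bear on it.

Measured so far in a functional assay on IGROV-1 cells (Homo sapiens) for cytotoxicity, read by sulforhodamine B assay, with a stated time of 48 h; on this read-out lower numbers stand for stronger inhibition of growth and higher numbers for weaker inhibition of growth:

compound 1, `ClCc1cccc(Cn2cnc3ncnc(Cl)c32)c1`: 13800 nM
compound 2, `ClCc1ccc(Cn2cnc3nc(Cl)nc(Cl)c32)cc1`: 2810 nM
compound 3, `ClCc1cccc(Cn2cnc3nc(Cl)nc(Cl)c32)c1`: 30900 nM

Compound 2 gives the lowest number of the three in this assay, and the values of compound 1 and compound 3 both lie clearly higher than it. Compound 2 and compound 3 share the same atoms joined differently; the difference between the two cores is not broken down here. Compound 3 and compound 1 differ in one place, (hydrogen in place of chloro on an aromatic carbon), and this change gave a 2.2-fold lower number from compound 3 to compound 1 (0.35 log units; beyond the scatter).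

Compound 4, `ClCc1ccc(Cn2cnc3ncnc(Cl)c32)cc1`, is not yet measured. It differs from compound 2 by hydrogen in place of chloro on an aromatic carbon, which is the same change as that from compound 3 to compound 1. On the assumption that the step repeats on the core of compound 2, the expected step is a 1.9-fold lower number from compound 2 to compound 4 (0.27 log units; within the scatter), resting on a 2.2-fold lower number from compound 3 to compound 1 (0.35 log units; beyond the scatter) as the single earlier occurrence. Compound 4 is therefore estimated at 1500 nM in this assay. The change has been seen only once, so the estimate for compound 4 is given with a wide range, from 500 nM to 4500 nM.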

Compound 4, concentration for total growth inhibition: 30900 nM
Compound 4: the middle estimate sits 21-fold (1.31 log units) below what was measured; measured number above the stated range.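

In this assay, hydrogen in place of chloro on an aromatic carbon, between two ring nitrogen atoms, gave an 11-fold higher number from compound 2 to compound 4 (1.04 log units; beyond the scatter), and the change did not carry over from one core to the other: the same change on two cores in this assay, a 2.2-fold lower number (0.35 log units; beyond the scatter) from compound 3 to compound 1 and an 11-fold higher number (1.04 log units; beyond the scatter) from compound 2 to compound 4, 25-fold (1.39 log units) apart, beyond the scatter of two such steps

Compound 2 and compound 3 share the same atoms joined differently, so within these four compounds the outcome of this change depends on which of the two cores carries it. With only two occurrences, the data do not show which step is more typical of the series, and they do not explain why the two steps differ.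

Still open, going by these compounds, is how an amine or a methoxy group at the same ring carbon would read on each core, compared with chloro or hydrogen. Also open, on these data alone, is whether a hydroxymethyl group or a longer chain in place of the chloromethyl group would leave the difference between the two cores intact.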